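Cyclohexyl for isopropyl on the ring amide nitrogen

This account rests on a few compounds, and the source may have more. Where it says the series, first, only, none or still open, it means among the compounds named here.

Three compounds of this series have numbers in a functional assay on HeLa cells (Homo sapiens) for antiproliferative activity, read by MTT assay, with a stated time of 72 h; a lower number here means a stronger inhibitor, a higher number a weaker inhibitor. Compound 1 `COc1ccc(N2C(=O)COc3ccc(-c4ccc(O)cc4)cc32)cc1` gives 16400 nM in this assay, compound 2 `O=C1COc2ccc(-c3cnc(Cl)c(NS(=O)(=O)c4ccc(F)cc4)c3)cc2N1` gives 15600 nM, and compound 3 `CC(C)N1C(=O)COc2ccc(-c3cccc(NS(=O)(=O)c4ccc(F)cc4)c3)cc21` gives 22700 nM. Compound 3 holds the highest of the three numbers, but its gap to compound 1 and its gap to compound 2 both lie within the usual scatter, so the three compounds cannot be set in any order of potency on these data.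

Compound 4 `O=C1COc2ccc(-c3cccc(NS(=O)(=O)c4ccc(F)cc4)c3)cc2N1C1CCCCC1` has not been measured in this assay. Compared with compound 3 the change is cyclohexyl in place of isopropyl on an amide-type nitrogen in a ring. For the measured compounds named here, no pair of measured compounds differs in this one place, so there is no measured step to guide the size of the effect; the three measured numbers sit close together despite differences at several positions. The step from compound 3 to compound 4 is therefore expected to be small, in either direction or none beyond the scatter. Compound 4 is estimated at 18000 nM, in a range of 7000 nM to 45000 nM, which means an expected step of a 1.3-fold lower number from compound 3 to compound 4 (0.10 log units; within the scatter).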

Compound 4, half-maximal inhibitory concentration: 10800 nM
Beside the measured number, compound 4's estimate is 1.7-fold (0.22 log units) above it; the range from low to high includes it.
By their numbers in this assay, from the lowest: compounds 4, 2, 1 and 3 (each within the scatter of the next, the first and the last beyond it).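

In this assay, for the compounds shown here, the ring amide nitrogen now has its first single-place comparison: cyclohexyl in place of isopropyl gives a 2.1-fold lower number from compound 3 to compound 4 (0.32 log units; beyond the scatter) and so this position does respond to its substituent, which the earlier compounds, differing in several places at once, could not show. The step is modest, but the larger cyclohexyl is accepted here with no loss of activity, and the change adds only carbon and one ring, with hydrogen-bond donors, acceptors and charge unchanged. Nothing available on these compounds accounts for the step.

From the compounds shown here alone, whether the trend depends on ring size or on carbon count stays open, as cyclopentyl or a longer chain such as n-hexyl would be needed to separate the two. Also open, going by these compounds, is how a polar group on this nitrogen, such as an aminoethyl chain or a carboxylic acid, would behave.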